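The source may report more compounds than this note shows. Statements on the series, on what has been measured and on what is new or still open speak of the compounds shown alone.

Working notes on the series. Going by the values given here, compound 1 `CCCCCC1(OC)CCN(c2ccc(C(=O)NS(=O)(=O)c3ccc(N[C@H](CCN(C)C)CSc4ccccc4)c([N+](=O)[O-])c3)cc2)CC1` is the reference point; in an assay on isolated protein for displacement of a labelled ligand from Apoptosis regulator Bcl-2 (Homo sapiens), read by fluorescence polarization (on this read-out lower numbers stand for stronger inhibition and higher numbers for weaker inhibition), compound 1 gives 20 nM, the highest of the three numbers measured so far. Compound 2 `COC1(Cc2cccc(Cl)c2)CCN(c2ccc(C(=O)NS(=O)(=O)c3ccc(N[C@H](CCN(C)C)CSc4ccccc4)c([N+](=O)[O-])c3)cc2)CC1` gives 1.8 nM and compound 3 `COC1(Cc2ccccc2Br)CCN(c2ccc(C(=O)NS(=O)(=O)c3ccc(N[C@H](CCN(C)C)CSc4ccccc4)c([N+](=O)[O-])c3)cc2)CC1` gives 1.5 nM. Putting an aryl group in place of the butyl on the saturated chain carbon bound to a saturated ring carbon has twice produced a large drop: an 11-fold lower number from compound 1 to compound 2 (1.05 log units; beyond the scatter) and a 13-fold lower number from compound 1 to compound 3 (1.12 log units; beyond the scatter). Between the two aryl variants the gap is small: a 1.2-fold lower number from compound 2 to compound 3 (0.08 log units; within the scatter), so the identity of the halogen and its ring position did not separate them here.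

Compound 4 `COC1(Cc2ccccc2-c2ccccc2)CCN(c2ccc(C(=O)NS(=O)(=O)c3ccc(N[C@H](CCN(C)C)CSc4ccccc4)c([N+](=O)[O-])c3)cc2)CC1` continues the same kind of replacement: 2-phenylphenyl in place of butyl on a saturated chain carbon bound to a saturated ring carbon. The precedents that bear on it are the two steps from compound 1, both large and both downward, each placing an aromatic ring at the same carbon. The second aromatic ring of the 2-phenylphenyl group has no precedent in this set, which widens the range but gives no reason to expect a different direction. The step is therefore expected to be large and downward, an 8.0-fold lower number from compound 1 to compound 4 (0.90 log units; beyond the scatter). Compound 4 is estimated at 2.5 nM, with a range from 0.8 nM to 8 nM.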

Compound 4, inhibition constant: < 1 nM
Compound 4: no number, only a limit; the forecaster's own chance of this, stated with the estimate: 0%; middle value at least 2.5-fold (0.39 log units) away from the limit.
By their numbers in this assay, from the lowest: compounds 3 and 2 (each within the scatter of the next); then compound 1. At a limit, below all of these: compound 4.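

Compound 4 in this assay gives < 1 nM, which is a limit of the assay and not a number, so the series now reaches the edge of what this read-out can resolve: the limit of < 1 nM in this assay, at which 1 of the 4 values shown sits.

At the saturated chain carbon bound to a saturated ring carbon, the 2-phenylphenyl group, with its 2 six-membered aromatic rings, keeps the large drop seen with a single aromatic ring, an at least 20-fold lower number from compound 1 to compound 4 (1.30 log units; beyond the scatter), so this position accepts the second ring with no loss. Against the two halogenated aryl variants, the floors are an at least 1.5-fold lower number from compound 3 to compound 4 (0.17 log units; that floor lies within the scatter) and an at least 1.8-fold lower number from compound 2 to compound 4 (0.25 log units; that floor lies within the scatter), so a gain from the second ring can be neither claimed nor ruled out.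

On these data alone, with only a limit for compound 4, the true size of any gain from the second aromatic ring remains unknown, as does how large a group this carbon accepts before the number rises again. The groups shown here carry no hydrogen-bond donors or acceptors, so it remains open whether an amine, a carboxylic acid or a pyridine ring at this carbon would hold the low numbers.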